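The source may hold more compounds than are shown below. What is called first, only, known or untested is meant among the compounds shown, and "the series" means these compounds.

Measured in an ADME assay on a cell-free system (plasma, Homo sapiens) for protein binding:
compound 1 `C[C@@H](Oc1cc2cnn(CCC(=O)O)c2cc1Cl)c1ccccn1`: 90.1%
compound 2 `COCCOc1cc2oc(=O)n(CCC(=O)O)c2cc1Cl`: 70.7%
compound 3 `Cc1ccc([C@@H](C)Oc2cc3oc(=O)n(CCC(=O)O)c3cc2Cl)nc1`: 97.8%

Compound 2 has the lowest binding of the three and so the highest unbound fraction. Its gaps to compound 1 and compound 3 both lie beyond the scatter.

The next compound is compound 4 `CCc1cc2oc(=O)n(CCC(=O)O)c2cc1Cl`, which has ethyl in place of 2-methoxyethoxy on an aromatic carbon. Among the measured compounds shown here, no measured pair differs in one place only, so there is no direct step to draw on. For the measured compounds named here, the only guide is indirect: compound 2 reads 70.7%, while compound 1 (90.1%) and compound 3 (97.8%), neither carrying 2-methoxyethoxy, both show more binding, although they differ from compound 2 in more than this one group. A modest rise in binding is therefore expected, with the estimate being a 1.6-fold lower unbound fraction from compound 2 to compound 4 (0.21 log units; within the scatter). For compound 4 the expected value in this assay is 82%, with an estimated range of 68% to 93%.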

Compound 4, plasma protein binding: 98.7%
Compound 4: the middle estimate sits 14-fold (1.14 log units) (unbound fraction) above what was measured, and the stated range ends below it.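

In this assay, among the compounds shown here, the aromatic carbon ortho to a chloro group proves highly sensitive to its substituent: ethyl in place of 2-methoxyethoxy gives a 23-fold lower unbound fraction from compound 2 to compound 4 (1.35 log units; beyond the scatter) in the only single-place comparison available so far. The size of this step shows that the group on this carbon can by itself move binding strongly, with the rest of the structure unchanged. Compound 4 reads 98.7% with ethyl, so a group of 2 heavy atoms and no hydrogen-bond acceptors is enough here to give very high binding.

The compounds shown do not separate the length of the chain from the presence of its oxygens; a methoxy group, a longer alkyl chain or an amine on this carbon would be needed to tell these apart. Nothing measured here gives a reason for the size of this step.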